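The source may hold more compounds than are shown below. What is called first, only, known or untested is meant among the compounds shown, and "the series" means these compounds.

For the measured compounds named here, in a functional assay on U-87MG ATCC cells for cytotoxicity against U-87 MG (Homo sapiens), read by MTT assay, with a stated time of 72 h (on this read-out lower numbers stand for stronger inhibition and higher numbers for weaker inhibition), compound 1 (`COc1ncc(-c2ccc3nc(NC(=O)N(C)C)nn3c2)cc1NS(=O)(=O)c1ccc(F)cc1`) gives 1780 nM and compound 2 (`COc1ncc(-c2ccc3nc(NC(=O)NCC(=O)N4CCOCC4)nn3c2)cc1NS(=O)(=O)c1ccc(F)cc1`) gives 3260 nM, so compound 2 stands within the scatter of the only other measured compound. Compound 3 (`CNC(=O)Nc1nc2ccc(-c3cnc(OC)c(NS(=O)(=O)c4ccc(F)cc4)c3)cn2n1`) differs from compound 2 by hydrogen in place of (morpholin-4-yl)carbonyl on a saturated chain carbon bound to an amide-type nitrogen, with hydrogen in place of (morpholin-4-yl)carbonyl on a saturated chain carbon bound to an amide-type nitrogen. Going by the values given here, only one measured step bears on this change: a 1.8-fold higher number from compound 1 to compound 2 (0.26 log units; within the scatter), which also altered the group on a carbonyl carbon. No step beyond the scatter is therefore expected in this assay. The estimated change is a 1.5-fold lower number from compound 2 to compound 3 (0.17 log units; within the scatter). For compound 3, the expected value is 2200 nM, within an estimated range of 900 nM to 5500 nM.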

Compound 3, half-maximal inhibitory concentration: 640 nM
For compound 3 the middle estimate is 3.4-fold (0.54 log units) above the measured one; measured number outside the range, below it.
By their numbers in this assay, from the lowest: compound 3; then compounds 1 and 2 (each within the scatter of the next).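

In this assay, the step of a 5.1-fold lower number from compound 2 to compound 3 (0.71 log units; beyond the scatter) shows that hydrogen in place of (morpholin-4-yl)carbonyl on a saturated chain carbon bound to an amide-type nitrogen moves the number beyond the scatter, which the earlier pair had not shown. Hydrogen in place of methyl on an amide-type nitrogen, read as a 2.8-fold lower number from compound 1 to compound 3 (0.44 log units; beyond the scatter), also lies beyond the scatter. No measurement shown accounts for either step.

The compounds shown leave open how an amine, a carboxylic acid or a longer chain on that saturated chain carbon would read in this assay.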